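Methyl on the outer aryl ring: expectation for compound 4

The source may report more compounds than this note shows. Statements on the series, on what has been measured and on what is new or still open speak of the compounds shown alone.

Measured in a functional assay on MCF7 cells (Homo sapiens) for cytotoxicity, read by MTT assay, with a stated time of 48 h; a lower number here means a stronger inhibitor, a higher number a weaker inhibitor:
compound 1 `COc1cc(COCc2cn(Cc3cc(-c4ccc(C)cc4)cnc3Cl)nn2)cc(OC)c1OC`: 146000 nM
compound 2 `COc1cc(C2=NOC(COCc3cn(Cc4cc(-c5ccccc5)cnc4Cl)nn3)C2)cc(OC)c1OC`: 14600 nM
compound 3 `COc1cc(COCc2cn(Cc3cc(-c4ccccc4)cnc3Cl)nn2)cc(OC)c1OC`: 86700 nM

Compound 2 gives the lowest of the three numbers in this assay; how its core differs from that of compound 3 is not broken down here. Between compound 3 and compound 1 the change is methyl in place of hydrogen on an aromatic carbon, and it made a 1.7-fold higher number from compound 3 to compound 1 (0.23 log units; within the scatter). Compound 4 `COc1cc(C2=NOC(COCc3cn(Cc4cc(-c5ccc(C)cc5)cnc4Cl)nn3)C2)cc(OC)c1OC` carries the same change relative to compound 2: methyl in place of hydrogen on an aromatic carbon, at the same place. In this assay the step is expected to be a 1.5-fold higher number from compound 2 to compound 4 (0.18 log units; within the scatter), a small shift that rests on compound 1, because its step of a 1.7-fold higher number from compound 3 to compound 1 (0.23 log units; within the scatter) stayed within the scatter. Compound 4 is therefore estimated at 22000 nM, most likely between 9000 nM and 55000 nM.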

Compound 4, half-maximal inhibitory concentration: 12900 nM
The estimate for compound 4 lay 1.7-fold (0.23 log units) above the measured number; the measured number falls inside the stated range.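

In this assay, methyl in place of hydrogen on an aromatic carbon gives a 1.1-fold lower number from compound 2 to compound 4 (0.05 log units; within the scatter), a step within the scatter. Set beside the earlier step, the change reads the same on both cores: the same change on two cores in this assay, a 1.7-fold higher number (0.23 log units; within the scatter) from compound 3 to compound 1 and a 1.1-fold lower number (0.05 log units; within the scatter) from compound 2 to compound 4, 1.9-fold (0.28 log units) apart, within the scatter of two such steps. For the compounds shown here, this shows that phenyl to 4-methylphenyl carries across these two cores without a detectable difference, but with only two pairs, one assay and both steps within the scatter, it does not show that the methyl has any effect of its own or that the agreement extends to other cores.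

Open, going by these compounds, is whether an amine, a carboxylic acid or trifluoromethyl in place of that methyl would move the number on either core. On these data alone, every methyl shown sits para to a large group, so other places on that ring also remain open.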